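Amide to trifluoroethoxymethyl ether on the shared core

The compounds below may be only part of what the source reports. "The series", "measured", "known", "first", "only" and "open" are said of these compounds alone.

Compound 2 `CCc1cccc2c(OC)c(-c3occ(C)c3C(=O)NC)ccc12` is known in a functional assay on DU-145 cells (Homo sapiens) for cytotoxicity, read by MTT assay, with a stated time of 72 h (a lower number here means that less compound is needed, a higher number that more compound is needed for the effect), only as a limit of the assay, where compound 2 gives > 10 ug/mL. Compound 1 `CCOc1c(-c2occ(C)c2C(=O)O)ccc2c(CC)cccc12` likewise sits at a limit, giving > 10 ug/mL in this assay. Compound 3 `CCc1cccc2c(OC)c(-c3occ(C)c3C(=O)On3nnc4ccccc43)ccc12` also stays at a limit, with > 10 ug/mL. The step from compound 2 to compound 3 a step that the two limits leave unreadable from compound 2 to compound 3 cannot be sized because of the limit of > 10 ug/mL in this assay, at which 3 of the 3 values shown sit. Compound 4 `CCc1cccc2c(OC)c(-c3occ(C)c3COCC(F)(F)F)ccc12` differs from compound 2 by (2,2,2-trifluoroethoxy)methyl in place of methylcarbamoyl on an aromatic carbon. For the measured compounds named here, no measured step bears on this change, and none of the three known values is a true number, so neither a direction nor a size can be read from them. Compound 4 is therefore expected to remain near the limit, at an estimated 15 ug/mL with a range from 4 ug/mL to 60 ug/mL. That corresponds to an expected step that the limit leaves unreadable from compound 2 to compound 4.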

Compound 4, concentration for half-maximal effect: 5.7 ug/mL
For compound 4 the middle estimate is 2.6-fold (0.42 log units) above the measured one; the measured number falls inside the stated range.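

In this assay, compound 4 is the only one of the compounds shown to give a true number rather than a limit, so (2,2,2-trifluoroethoxy)methyl on this aromatic carbon gives a readable result where methylcarbamoyl did not. The change gives an at least 1.7-fold lower number from compound 2 to compound 4 (0.24 log units; that floor lies within the scatter). Its true size stays unknown, and that floor alone does not separate the two compounds: the limit of > 10 ug/mL in this assay, at which 3 of the 4 values shown sit.

From the compounds shown here alone, whether the fluorines or the ether oxygen matter more stays open. A plain ethoxymethyl or hydroxymethyl group on the same carbon would bear on that question.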